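Indazole switch at the diaryl olefin: notes on compound 4

This account rests on a few compounds, and the source may have more. Where it says the series, first, only, none or still open, it means among the compounds named here.

Measured so far in a functional assay on MCF7 cells (Homo sapiens) for cytotoxicity, read by CellTiter-Glo, with a stated time of 5 days; on this read-out lower numbers stand for stronger inhibition and higher numbers for weaker inhibition:
- compound 1 `O=C(O)/C=C/c1ccc(/C(=C(\c2ccccc2)C2CCC2)c2ccc3[nH]ncc3c2)cc1`: 1.4 nM
- compound 2 `O=C(O)/C=C/c1ccc(/C(=C(\c2ccccc2)C2CCCC2)c2ccc3[nH]ncc3c2)cc1`: 10 nM
- compound 3 `CC/C(=C(/c1ccc(/C=C/C(=O)O)cc1)c1cc2cn[nH]c2cn1)c1ccccc1`: 442 nM

Compound 3 gives the highest number of the three in this assay; compound 2 sits well below it and compound 1 lower still. Compound 4 `CC/C(=C(/c1ccc(/C=C/C(=O)O)cc1)c1cc2cn[nH]c2cc1C)c1ccccc1` differs from compound 3 by a group of 10 heavy atoms (8 carbon, 2 nitrogen; one five-membered aromatic ring with 2 hetero atoms, one six-membered aromatic ring of carbon only) in place of a group of 9 heavy atoms (6 carbon, 3 nitrogen; one five-membered aromatic ring with 2 hetero atoms, one six-membered aromatic ring with 1 hetero atom), on a double-bonded chain carbon bound to an aromatic carbon and a double-bonded chain carbon. Going by the values given here, the only measured step, a 7.1-fold higher number from compound 1 to compound 2 (0.85 log units; beyond the scatter), changes a different place, so no step bears directly on this change. The carbocyclic indazole is shared by compound 1 and compound 2, both far below compound 3, though their chain groups also differ. A lower number is therefore expected for compound 4, a 7.4-fold lower number from compound 3 to compound 4 (0.87 log units; beyond the scatter), as a modest step. Compound 4 is estimated at 60 nM, within 12 nM to 300 nM.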

Compound 4, half-maximal inhibitory concentration: 468 nM
The estimate for compound 4 lay 7.8-fold (0.89 log units) below the measured number, and the stated range ends below it.
By their numbers in this assay, from the lowest: compound 1; then compound 2; then compounds 3 and 4 (each within the scatter of the next).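

Replacing the group left by compound 3 with 6-methyl-1H-indazol-5-yl gives a 1.1-fold higher number from compound 3 to compound 4 (0.02 log units; within the scatter) in this assay at this place, on a double-bonded chain carbon bound to an aromatic carbon and a double-bonded chain carbon. The read-out therefore does not tell these two groups apart on this shared core. No measurement on hand accounts for this result.

The ring change and the methyl arrive together in this step, so their separate contributions cannot be read. From the compounds shown here alone, whether fluoro or methoxy in place of that methyl, or unsubstituted 1H-indazol-5-yl on this same core, would read differently remains open.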